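A few compounds are considered here, and "the series" means these few. Any claim that something is new, unique, unknown or untested is made for them only; others in the source may bear on it.

Compound 2 `CN(C)CCCCOc1ccccc1/C=C/c1ccccc1Cl` is measured in a functional assay on the whole organism with Mus musculus as the target, in the maximal electroshock model, at a dose of 50 mg/kg by the oral route (a lower number here means less inhibition, a higher number more inhibition at the dose given (going by the name of the read-out)), where compound 2 gives 14.3%. Among the compounds with values here, that sits at the top of the two numbers so far, yet compound 1 `CN(C)CCCOc1ccccc1/C=C/c1ccccc1` gives 14.2% in this assay, and the gap between the two lies within the scatter, so the two numbers are level. Compound 3 `CN(C)CCCCOc1ccccc1/C=C/c1cccc(Cl)c1` has not yet been measured in this assay. It differs from compound 2 by 3-chlorophenyl in place of 2-chlorophenyl on a double-bonded chain carbon bound to a double-bonded chain carbon. Within the data shown here, no measured pair shows a comparable change. The step of a number 0.7 percentage points higher from compound 2 to compound 3 (within the scatter) is expected to be small, with no direction beyond the scatter. Compound 3 is therefore estimated at 15%, between 4% and 32%.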

Compound 3, a percentage reported as inhibition, in the whole organism at one dose (the size of the read-out at that dose, not a potency): 14.3%
Estimate against measurement, compound 3: 0.7 percentage points above; low and high end bracket the measured number.
By their numbers in this assay, from the lowest: compounds 1, 2 and 3 (each within the scatter of the next).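

Placing 3-chlorophenyl in place of 2-chlorophenyl on a double-bonded chain carbon bound to a double-bonded chain carbon gives no change at the digits printed from compound 2 to compound 3 (within the scatter) in this assay. Within the data shown here, this is the only comparison here between compounds that differ in one place, and at this single dose the read-out does not separate these two chlorophenyl groups. No measurement at hand bears on this result. As far as these compounds go, whether a methoxy group or a nitrile in place of the chlorine would shift the number stays open. From the compounds shown here alone, the effect of the chain alone also stays open, as compound 1 and compound 2 differ in more than one place.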